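The source may report more compounds than this note shows. Statements on the series, on what has been measured and on what is new or still open speak of the compounds shown alone.

In an ADME assay on HEp-2 cells (Homo sapiens) for cytotoxicity, with a stated time of 4 days (on this read-out higher numbers stand for lower toxicity in this test and lower numbers for higher toxicity in this test), compound 1, `CS(=O)(=O)CCn1c(Cn2cc(S(C)(=O)=O)c3ccccc32)nc2ccccc21`, gives > 100000 nM, which is a limit of the test and not a measured number. Compound 2, `CC(C)(CO)Cn1c(Cn2nc(S(C)(=O)=O)c3ccncc32)nc2cc(Cl)ccc21`, gives > 100000 nM in this assay, again only a limit. Both values therefore sit at the limit of > 100000 nM in this assay, at which 2 of the 2 values shown sit. Compound 3, `CS(=O)(=O)c1nn(Cc2nc3cc(Cl)ccc3n2CCCCC(F)(F)F)c2cnccc12`, differs from compound 2 by 4,4,4-trifluorobutyl in place of 1-(hydroxymethyl)-1-methylethyl on a saturated chain carbon bound to an aromatic nitrogen. Going by the values given here, no step between two measured compounds is available to guide the expectation, so the step is expected to be a number no higher from compound 2 to compound 3 (the limit leaves the size open), nothing beyond the usual scatter. Compound 3 is estimated at 100000 nM, within 30000 nM to 300000 nM, and most likely the test will again report only a limit.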

Compound 3, half-maximal cytotoxic concentration: > 100000 nM
Compound 3 ended at the assay's limit; the forecaster's own chance of this, stated with the estimate: 70%; the middle value lies on the limit itself.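

No size can be read for the change from compound 2 to compound 3, as both values are only limits of the test: the limit of > 100000 nM in this assay, at which 3 of the 3 values shown sit. The compounds shown leave open what concentration, if any, would reach the half-maximal cytotoxic point in this assay, and whether this change shifts it.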